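Fluoro for methoxy in a curcuminoid pair

This account rests on a few compounds, and the source may have more. Where it says the series, first, only, none or still open, it means among the compounds named here.

Measured compounds:
compound 1, `COc1ccc(/C=C/C(=O)C(=Cc2ccc(O)c(OC)c2)C(=O)/C=C/c2ccc(OC)cc2OC)c(OC)c1`, 1520 nM
compound 2, `COc1ccc(/C=C/C(=O)C(=Cc2ccc(O)c(F)c2)C(=O)/C=C/c2ccc(OC)cc2OC)c(OC)c1`, 3350 nM
compound 3, `COc1cc(OC)c(/C=C/C(=O)C(=Cc2ccc(O)c(OC)c2)C(=O)/C=C/c2c(OC)cc(OC)cc2OC)c(OC)c1`, 1490 nM

In a functional assay on SW480 cells (Homo sapiens) for antiproliferative activity, read by sulforhodamine B assay, with a stated time of 48 h (a lower number here means a stronger inhibitor, a higher number a weaker inhibitor), compound 1 gives 1520 nM. Its partner compound 2 carries the change (fluoro in place of methoxy on an aromatic carbon), and the step is a 2.2-fold higher number from compound 1 to compound 2 (0.34 log units; beyond the scatter). Compound 3, built on a different core, gives 1490 nM in this assay; its value and that of compound 1 lie within the scatter of each other, so no order between them is claimed. The difference between the two cores is not broken down here.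

Compound 4, `COc1cc(OC)c(/C=C/C(=O)C(=Cc2ccc(O)c(F)c2)C(=O)/C=C/c2c(OC)cc(OC)cc2OC)c(OC)c1`, is not yet measured. It differs from compound 3 by fluoro in place of methoxy on an aromatic carbon, at the same place as in the pair of compound 1 and compound 2. Within the data shown here, since the change is the same and the only measured example of it gave a 2.2-fold higher number from compound 1 to compound 2 (0.34 log units; beyond the scatter), a step of similar size is expected from compound 3 to compound 4, namely a 2.1-fold higher number from compound 3 to compound 4 (0.33 log units; beyond the scatter). Compound 4 is thus estimated at 3200 nM in this assay, between 1800 nM and 6000 nM.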

Compound 4, half-maximal inhibitory concentration: 1950 nM
Compound 4: middle estimate off by 1.6-fold (0.22 log units), on the high side; the range from low to high includes it.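

In this assay, the step on the second core is a 1.3-fold higher number from compound 3 to compound 4 (0.12 log units; within the scatter), so on this core the swap of methoxy for fluoro leaves no difference that can be told from repeat measurement. Set beside the step on the first core, it does not differ by more than two such steps may scatter: the same change on two cores in this assay, a 2.2-fold higher number (0.34 log units; beyond the scatter) from compound 1 to compound 2 and a 1.3-fold higher number (0.12 log units; within the scatter) from compound 3 to compound 4, 1.7-fold (0.23 log units) apart, within the scatter of two such steps. The two cores are therefore consistent with one shared step, but two pairs do not show that the step has a fixed size, that it would carry to any further core, or that the change truly matters on one core and not on the other.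

The compounds shown leave open what other groups would do at this place, such as a chloro group or an amine in place of the methoxy. They also leave open whether the same step would appear if the neighbouring hydroxy group gave way to a methoxy or an amine.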